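Carbonyl-linked ring variation on the shared core

The source may hold more compounds than are shown below. What is called first, only, known or untested is meant among the compounds shown, and "the series" means these compounds.

Measured so far: compound 1 `Cc1c(C(C)C)c(=O)on1C(=O)N1CCCC1` and compound 2 `Cc1c(C(C)C)c(=O)on1C(=O)N1CC=CC1`.

In an assay (strain Wistar) for inhibition of Hormone-sensitive lipase (Rattus norvegicus), read by spectrophotometry (a higher number here means a weaker inhibitor, a lower number a stronger inhibitor), compound 1 gives 15 nM. In this assay, going by the values given here, compound 2 gives 72 nM, the highest of the two numbers; its only neighbour is compound 1, with the step of a 4.8-fold higher number from compound 1 to compound 2 (0.68 log units; beyond the scatter). That step shows that exchange of the ring on the carbonyl carbon does move the numbers beyond the scatter.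

Compound 3 `Cc1c(C(C)C)c(=O)on1C(=O)N1CCOCC1` is not yet measured in this assay. It differs from compound 2 by a group of 6 heavy atoms (4 carbon, 1 nitrogen, 1 oxygen; one six-membered non-aromatic ring with 2 hetero atoms) in place of a group of 5 heavy atoms (4 carbon, 1 nitrogen; one five-membered non-aromatic ring with 1 hetero atom), on a carbonyl carbon. Among the compounds with values here, no measured step covers the entry of morpholin-4-yl; the one step on this carbonyl carbon, from compound 1 to compound 2, is a modest weakening and gives no direction for compound 3. Compound 3 is therefore expected near the present numbers, with the step of a 1.6-fold lower number from compound 2 to compound 3 (0.20 log units; within the scatter) estimated as small. The estimate for compound 3 is 45 nM, expected between 10 nM and 180 nM.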

Compound 3, half-maximal inhibitory concentration: 52 nM
For compound 3 the middle estimate is 1.2-fold (0.06 log units) below the measured one, and the stated range covers the measured number.
By their numbers in this assay, from the lowest: compound 1; then compounds 3 and 2 (each within the scatter of the next).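

In this assay the entry of morpholin-4-yl in place of pyrrolidin-1-yl on the carbonyl carbon gives a 3.5-fold higher number from compound 1 to compound 3 (0.54 log units; beyond the scatter) and so is a second ring exchange at this place that moves the number beyond the scatter. The same group set against the ring of compound 2 gives a 1.4-fold lower number from compound 2 to compound 3 (0.14 log units; within the scatter) and leaves compounds 2 and 3 indistinguishable, so that among the three compounds only compound 1, with the lowest number, stands apart. Nothing on hand offers an explanation for these differences.

Open, from the compounds shown here alone, is whether piperidin-1-yl, an open-chain dimethylamino group or a pyrrolidine ring bearing a carboxylic acid on this carbonyl carbon would stay near compound 1 or near compounds 2 and 3. Also open, going by these compounds, is whether the gap between these rings would hold on any core other than the shared one.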